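Aryl ether variation and cytotoxicity in the shared core

The source may report more compounds than this note shows. Statements on the series, on what has been measured and on what is new or still open speak of the compounds shown alone.

Compound 3 `N#Cc1ccc(Nc2nc(Oc3ccc(Cl)cc3)c3ccccc3n2)cc1` gives 198000 nM in an ADME assay on MT4 cells (Homo sapiens) for cytotoxicity, read by MTT assay, with a stated time of 4 days (on this read-out higher numbers stand for lower toxicity in this test and lower numbers for higher toxicity in this test), the second highest of the three numbers: compound 1 `COc1ccc(Oc2nc(Nc3ccc(C#N)cc3)nc3ccccc23)cc1` gives 340000 nM, a gap within the scatter, while compound 2 `Cc1cc(Br)c(Oc2nc(Nc3ccc(C#N)cc3)nc3ccccc23)c(Br)c1` gives 25000 nM, the step of a 7.9-fold higher number from compound 2 to compound 3 (0.90 log units; beyond the scatter) lying beyond it. Compound 4 `Cc1cc(C)c(Oc2nc(Nc3ccc(C#N)cc3)nc3ccccc23)c(C)c1` carries 2,4,6-trimethylphenyl in place of 4-chlorophenyl on an oxygen on an aromatic ring. The step of a 7.9-fold higher number from compound 2 to compound 3 (0.90 log units; beyond the scatter) bears most on this change, since compound 2 with its 2,6-dibromo-4-methylphenyl is the nearer analogue of compound 4; the step of a 14-fold lower number from compound 1 to compound 2 (1.13 log units; beyond the scatter) points the same way. A modest step toward a lower number in this assay is therefore expected, though less than the full return to compound 2, as the bromines do not come back. Compound 4 is expected at 70000 nM (range 25000 nM to 200000 nM), an estimated step of a 2.8-fold lower number from compound 3 to compound 4 (0.45 log units; beyond the scatter).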

Compound 4, half-maximal cytotoxic concentration: > 34000 nM
Compound 4 ended at the assay's limit; the forecaster's own chance of this, stated with the estimate: 10%; the middle value does not contradict the limit.
By their numbers in this assay, from the lowest: compound 2; then compounds 3 and 1 (each within the scatter of the next).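

In this assay compound 4 gives > 34000 nM, a limit of the assay and not a number. For the compounds shown here, the only readable change is an at least 1.3-fold higher number from compound 2 to compound 4 (0.13 log units; that floor lies within the scatter), a floor that does not separate 2,4,6-trimethylphenyl from 2,6-dibromo-4-methylphenyl on this oxygen. The steps to compound 4 from compound 3 and compound 1 cannot be read, because the reading stops at the limit: the limit of > 34000 nM in this assay, at which 1 of the 4 values shown sits.

Where compound 4 truly lies relative to compound 1 and compound 3 stays open. Also open, from the compounds shown here alone, is how a phenyl carrying an amine or a carboxylic acid would read on this oxygen.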